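Phenyl for methyl on a fluorinated pyranopyrazole

The source may report more compounds than this note shows. Statements on the series, on what has been measured and on what is new or still open speak of the compounds shown alone.

Compound 1, `COc1ccc(C2C(C#N)=C(N)Oc3c2c(-c2ccccc2)nn3C)cc1`: > 10000 nM
Compound 2, `COc1ccc(C2C(C#N)=C(N)Oc3c2c(C)nn3C)cc1F`: 5800 nM

Within the data shown here, in a functional assay on NCI-H2122 cells (Homo sapiens) for inhibition, read by microscopy, with a stated time of 10 days (on this read-out higher numbers stand for weaker inhibition and lower numbers for stronger inhibition), compound 2 gives 5800 nM, the only numeric value shown for the series. Compound 1 is reported only as a limit of the assay, > 10000 nM. Compound 3, `COc1ccc(C2C(C#N)=C(N)Oc3c2c(-c2ccccc2)nn3C)cc1F`, is not yet measured. It differs from compound 2 by phenyl in place of methyl on an aromatic carbon. Among the measured compounds shown here, no measured pair in this set carries that same change, so no step size is on record for it. What is known is that one of the two values sits at the limit of > 10000 nM in this assay, at which 1 of the 2 values shown sits, and compound 1 is the one that carries the phenyl. That limit weighs on the expectation. Compound 3 is therefore estimated at 9000 nM, within a range from 3000 nM to 30000 nM. The step of a 1.6-fold higher number from compound 2 to compound 3 (0.19 log units; within the scatter) is thus expected to run toward weaker inhibition, with a fair chance that only a limit is returned.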

Compound 3, half-maximal inhibitory concentration: > 10000 nM
Compound 3 gave a limit, no number; the forecaster's own chance of this, stated with the estimate: 55%; at least 1.1-fold (0.04 log units) between middle value and limit.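

With the fluoro held constant, phenyl in place of methyl on this aromatic carbon gives an at least 1.7-fold higher number from compound 2 to compound 3 (0.23 log units; that floor lies within the scatter) in this assay, and compound 3 is a limit, so this step is only a floor. The earlier compounds shown here offered no such pair, since compound 1 and compound 2 differ in two places. Both phenyl compounds now stand at the limit, so the step for fluoro in place of hydrogen between them cannot be read, and the values shown gather there: the limit of > 10000 nM in this assay, at which 2 of the 3 values shown sit.

On these data alone, how far the true values of compound 1 and compound 3 lie past that limit stays open, and with it the real size of the phenyl step. Also open, as far as these compounds go, is how an ethyl chain, a cyclopropyl ring or an amine would read at this aromatic carbon in the same assay.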